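The source may report more compounds than this note shows. Statements on the series, on what has been measured and on what is new or still open speak of the compounds shown alone.

Measured compounds in a functional assay on CCRF-CEM cells (Homo sapiens); on this read-out lower numbers stand for higher toxicity in this test and higher numbers for lower toxicity in this test:
- compound 1 `Cc1cn([C@@H]2O[C@H](CO[Si](C)(C)C(C)(C)C)[C@@]3(OS(=O)(=O)C=C3NC(N)=O)[C@H]2O[Si](C)(C)C(C)(C)C)c(=O)n(C)c1=O` gives 4360 nM
- compound 2 `COC(=O)CC(=O)NC1=CS(=O)(=O)O[C@@]12[C@@H](CO[Si](C)(C)C(C)(C)C)O[C@@H](n1cc(C)c(=O)n(C)c1=O)[C@@H]2O[Si](C)(C)C(C)(C)C` gives 29700 nM
- compound 3 `COC(=O)CCNC1=CS(=O)(=O)O[C@@]12[C@@H](CO[Si](C)(C)C(C)(C)C)O[C@@H](n1cc(C)c(=O)n(C)c1=O)[C@@H]2O[Si](C)(C)C(C)(C)C` gives only a limit, > 250000 nM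

Within the data shown here, compound 3 thus stands at the upper edge of the three values, as the one compound whose result is a limit rather than a number (the limit of > 250000 nM in this assay, at which 1 of the 3 values shown sits). Compound 4 `Cc1cn([C@@H]2O[C@H](CO[Si](C)(C)C(C)(C)C)[C@@]3(OS(=O)(=O)C=C3NCC(=O)C(=O)O)[C@H]2O[Si](C)(C)C(C)(C)C)c(=O)n(C)c1=O` differs from it by carboxycarbonyl in place of (methoxycarbonyl)methyl on a saturated chain carbon bound to an amine nitrogen. Among the measured compounds shown here, no measured step repeats this change; the nearest are an at least 8.4-fold higher number from compound 2 to compound 3 (0.92 log units; beyond the scatter) and an at least 57-fold higher number from compound 1 to compound 3 (1.75 log units; beyond the scatter), both ending at compound 3. Compound 4 keeps the saturated chain carbon on the amine nitrogen, so the same region is expected, and an at least 1.2-fold lower number from compound 3 to compound 4 (0.09 log units; that floor lies within the scatter) is estimated as a step not beyond the scatter. Compound 4 is therefore expected at 200000 nM, within 30000 nM to 800000 nM.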

Compound 4, half-maximal cytotoxic concentration: 72600 nM
Beside the measured number, compound 4's estimate is 2.8-fold (0.44 log units) above it; the measured number falls inside the stated range.
By their numbers in this assay, from the lowest: compound 1; then compound 2; then compound 4. At a limit, above all of these: compound 3.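

In this assay, the saturated chain carbon bound to an amine nitrogen proves responsive to its substituent: carboxycarbonyl in place of (methoxycarbonyl)methyl gives an at least 3.4-fold lower number from compound 3 to compound 4 (0.53 log units; beyond the scatter), restoring a measurable number on this chain. The reference for that step is only a limit for compound 3: the limit of > 250000 nM in this assay, at which 1 of the 4 values shown sits. The new number still stands apart from those with a carbonyl directly on the amine nitrogen, with a 2.4-fold higher number from compound 2 to compound 4 (0.39 log units; beyond the scatter) and a 17-fold higher number from compound 1 to compound 4 (1.22 log units; beyond the scatter).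

The compounds shown leave open whether the carboxylic acid or the carbonyl entering with it matters more. A carboxymethyl group, or the methyl ester of carboxycarbonyl, on that carbon could separate the two.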